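This account rests on a few compounds, and the source may have more. Where it says the series, first, only, none or still open, it means among the compounds named here.

The study follows three related compounds in a functional assay on HepG2 cells (Homo sapiens) for antiproliferative activity, read by MTT assay, with a stated time of 48 h; on this read-out lower numbers stand for stronger inhibition and higher numbers for weaker inhibition. Compound 1, with the structure `Cc1ccc(Cl)cc1-n1nncc1CN1C(=O)C2(C(C#N)=C(N)Oc3c2c2nc4ccccc4nc2c2ccccc32)c2ccccc21`, returned only a limit of the assay: in this assay compound 1 gives > 50000 nM. Going by the values given here, compound 2, with the structure `N#CC1=C(N)Oc2c(N)cc3nc4ccccc4nc3c2C12C(=O)N(Cc1cnnn1-c1cccc(C(F)(F)F)c1)c1ccccc12`, is the one compound with an actual number: in this assay compound 2 gives 15800 nM. On the numbers shown, compound 2 therefore stands alone as the only measured value. The remaining result is the limit of > 50000 nM in this assay, at which 1 of the 2 values shown sits. Compound 1 and compound 2 differ at more than one place, so their results are simply set side by side without a measured step between them.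

Compound 3, with the structure `Cc1ccc(C)c(-n2nncc2CN2C(=O)C3(C(C#N)=C(N)Oc4c(N)cc5nc6ccccc6nc5c43)c3ccccc32)c1`, has not been measured yet. It departs from compound 2 by a single exchange: 2,5-dimethylphenyl in place of 3-(trifluoromethyl)phenyl on an aromatic nitrogen. The remainder of the molecule is kept. Among the compounds with values here, no measured step offers a guide to this exchange. Compound 3 is expected to stay near compound 2, with a step of a 1.3-fold higher number from compound 2 to compound 3 (0.10 log units; within the scatter) that is not expected to go beyond the usual scatter in either direction. Compound 3 is estimated at 20000 nM, within a range from 6000 nM to 60000 nM.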

Compound 3, half-maximal inhibitory concentration: > 50000 nM
Compound 3 was reported as a limit; the forecaster's own chance of this, stated with the estimate: 30%; at least 2.5-fold (0.39 log units) between middle value and limit.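

In this assay, exchanging 3-(trifluoromethyl)phenyl for 2,5-dimethylphenyl on an aromatic nitrogen of the five-membered aromatic ring with 3 nitrogen gives a step that can be read, and this step lies beyond the scatter: an at least 3.1-fold higher number from compound 2 to compound 3 (0.50 log units; beyond the scatter). The result for compound 3 is a limit of the assay, so the step gives only the smallest size the change can have. The position is therefore not indifferent to the group it carries, since with the remainder of the molecule kept, this one exchange moves the read-out from a number to the limit: the limit of > 50000 nM in this assay, at which 2 of the 3 values shown sit.

As far as these compounds go, the exchange removes the trifluoromethyl group and brings in two methyl groups in a single move, and which part of it carries the step remains open. Also open, from the compounds shown here alone, is how an unsubstituted phenyl, or a phenyl bearing an amine or a carboxylic acid, would read at this position, and whether any group there would take the result past compound 2 at 15800 nM.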